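From 2-hydroxyphenyl to 3-hydroxyphenyl: a small structural step

This account rests on a few compounds, and the source may have more. Where it says the series, first, only, none or still open, it means among the compounds named here.

Compound 1 `C#CCSc1nc(NCCC#N)c2ccncc2n1`: > 80000 nM (a limit, not a number)
Compound 2 `C#CCSc1nc(Nc2ccc(Br)cc2)c2ccncc2n1`: 26000 nM
Compound 3 `C#CCSc1nc(Nc2ccccc2O)c2ccncc2n1`: 21000 nM

All three compounds were tested in a functional assay on MGC-803 cells (Homo sapiens) for inhibition, read by MTT assay, with a stated time of 72 h; a lower number here means a stronger inhibitor, a higher number a weaker inhibitor. There, compound 3 gives 21000 nM, and compound 2 gives 26000 nM. The step between them, a 1.2-fold lower number from compound 2 to compound 3 (0.09 log units; within the scatter), is within the scatter, so these two cannot be told apart and together hold the lower end of the numbers. Compound 1 reached only a limit of the assay, > 80000 nM. Replacing its 2-cyanoethyl group with a substituted phenyl gave an at least 3.0-fold lower number from compound 1 to compound 2 (0.48 log units; beyond the scatter) and an at least 3.8-fold lower number from compound 1 to compound 3 (0.58 log units; beyond the scatter). Both steps are beyond the scatter, but each starts from a limit, so its true size is not known.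

Compound 4 `C#CCSc1nc(Nc2cccc(O)c2)c2ccncc2n1` has 3-hydroxyphenyl in place of 2-hydroxyphenyl on a nitrogen on an aromatic ring. For the measured compounds named here, no measured pair tests this exact change. The closest guide is the exchange of 4-bromophenyl for 2-hydroxyphenyl, a 1.2-fold lower number from compound 2 to compound 3 (0.09 log units; within the scatter), which stayed within the scatter. A step beyond the scatter in this assay is therefore not expected, and the expected change is a 1.1-fold lower number from compound 3 to compound 4 (0.02 log units; within the scatter). For compound 4 the estimated value is 20000 nM, with an expected range from 8000 nM to 50000 nM.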

Compound 4, half-maximal inhibitory concentration: 15700 nM
Beside the measured number, compound 4's estimate is 1.3-fold (0.11 log units) above it, within the range that was stated.
By their numbers in this assay, from the lowest: compounds 4, 3 and 2 (each within the scatter of the next). At a limit, above all of these: compound 1.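

In this assay, exchanging 2-hydroxyphenyl for 3-hydroxyphenyl, two groups with the same atoms joined differently, gives a 1.3-fold lower number from compound 3 to compound 4 (0.13 log units; within the scatter), so moving the hydroxyl group around this phenyl ring produces no change that can be told apart from ordinary scatter. Exchanging 4-bromophenyl for 3-hydroxyphenyl gives a 1.7-fold lower number from compound 2 to compound 4 (0.22 log units; within the scatter), also within the scatter, so compound 2, compound 3 and compound 4 cannot be separated, even though the bromine-bearing ring and the hydroxyl-bearing rings carry different substituents. The remaining step, an at least 5.0-fold lower number from compound 1 to compound 4 (0.70 log units; beyond the scatter), is beyond the scatter and adds a third phenyl group that differs clearly from the 2-cyanoethyl group, but compound 1 stands at a limit, so the true size of this step stays unknown: the limit of > 80000 nM in this assay, at which 1 of the 4 values shown sits.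

The compounds shown leave open whether the substituent on the phenyl ring matters at all, a question that a plain phenyl group would help to answer. They also leave open whether a phenyl ring carrying an amine or a carboxylic acid, or a longer chain on this nitrogen, would move the number outside the narrow band these three compounds share.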